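The source may report more compounds than this note shows. Statements on the series, on what has been measured and on what is new or still open speak of the compounds shown alone.

Three compounds have been run in a functional assay on HCT-116 cells (Homo sapiens) for antiproliferative activity, read by CCK-8 assay, with a stated time of 72 h, tested at 2 uM; on this read-out lower numbers stand for a weaker effect and higher numbers for a stronger effect at the one concentration tested. Compound 1, `COC(CCn1cnc2c(NCc3ccc(C(=O)Nc4ccccc4N)cc3)nc(Cl)nc21)OC`, gives 6.39%. Compound 2, `CC(C)n1cnc2c(Nc3ccccc3)nc(NCOCc3ccc(/C=C/C(=O)Nc4ccccc4N)cc3)nc21`, gives 2.53%. Compound 3, `CC(C)n1cnc2c(Nc3cccc(Cl)c3)nc(NCOCc3ccc(C(=O)Nc4ccccc4N)cc3)nc21`, gives 7.12%. Compound 2 shows the smallest of the three numbers, yet its gaps to compound 1 and to compound 3 both lie within the scatter, so the three are not told apart in this assay.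

Compound 4, `Nc1ccccc1NC(=O)/C=C/c1ccc(COCNc2nc(Nc3ccccc3)c3ncn(C4CCCC4)c3n2)cc1`, differs from compound 2 by a single change: cyclopentyl in place of isopropyl on an aromatic nitrogen. Among the compounds with values here, no pair of measured compounds shows this change, so nothing in the data sets its size. Compound 4 is therefore expected to sit near compound 2, with a step of a number 1.5 percentage points higher from compound 2 to compound 4 (within the scatter) in this assay not beyond the scatter. The estimate for compound 4 is 4%, within -5% to 15%.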

Compound 4, a percentage reported as inhibition, at one concentration (the size of the read-out at that concentration, not a potency): 10.5%
For compound 4 the middle estimate is 6.5 percentage points below the measured one; low and high end bracket the measured number.
By their numbers in this assay, from the lowest: compounds 2, 1, 3 and 4 (each within the scatter of the next).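

In this assay, within the data shown here, the first pair to show cyclopentyl in place of isopropyl on this aromatic nitrogen gives a number 8 percentage points higher from compound 2 to compound 4 (within the scatter). The position therefore takes a five-membered non-aromatic ring of carbon only, with no difference that can be told from the scatter. Nothing measured here bears on the reason for the numbers of this pair. As far as these compounds go, whether a cyclohexyl ring or a longer chain on the same nitrogen would read beyond the scatter remains open. So does whether this change gives a similar step in compounds that differ elsewhere from compound 2.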